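The source may report more compounds than this note shows. Statements on the series, on what has been measured and on what is new or still open speak of the compounds shown alone.

Measured in a functional assay on A2780 cells (Homo sapiens) for antiproliferative activity, read by CellTiter-Glo, with a stated time of 72 h; a lower number here means a stronger inhibitor, a higher number a weaker inhibitor:
- Compound 1 `Nc1ccc(CNC(=O)Nc2ccc(CN3C(=O)c4ccccc4C3=O)cc2)cn1`: 100 nM
- Compound 2 `O=C(Nc1ccc(CN2Cc3ccccc3C2=O)cc1)N1CC(c2cccnc2)C1`: 0.6 nM
- Compound 3 `C[C@@H](c1ccc(NC(=O)N2CC(c3cccnc3)C2)cc1)N1Cc2ccccc2C1=O`: 1.5 nM

In this assay, compound 3 at 1.5 nM has the second highest of the three numbers, above compound 2 and below compound 1. The next compound, compound 4 `C[C@H](NC(=O)C1CCOCC1)c1ccc(NC(=O)N2CC(c3cccnc3)C2)cc1`, keeps most of compound 3 but changes one group: a group of 9 heavy atoms (6 carbon, 1 nitrogen, 2 oxygen; one six-membered non-aromatic ring with 1 hetero atom) in place of a group of 10 heavy atoms (8 carbon, 1 nitrogen, 1 oxygen; one five-membered non-aromatic ring with 1 hetero atom, one six-membered aromatic ring of carbon only), on a saturated chain carbon bound to an aromatic carbon and a saturated chain carbon. The incoming group is ((oxan-4-yl)carbonyl)amino.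

Among the measured compounds shown here, only one measured step bears on this change: a 2.5-fold higher number from compound 2 to compound 3 (0.40 log units; beyond the scatter). It was modest and came from adding just a methyl, so it says little about swapping a whole group. Compound 1 differs from the others in more than one place, so it offers no clean comparison. For the measured compounds named here, no measured compound carries the incoming group, which leaves the size of the step uncertain. A weaker result is still expected, an estimated 4.0-fold higher number from compound 3 to compound 4 (0.60 log units; beyond the scatter). For compound 4 the estimated value is 6 nM, with an expected range of 1.5 nM to 30 nM.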

Compound 4, half-maximal inhibitory concentration: 17 nM
Compound 4: the middle estimate sits 2.8-fold (0.45 log units) below what was measured; measured number inside the range.
By their numbers in this assay, from the lowest: compound 2; then compound 3; then compound 4; then compound 1.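

In this assay, the step to ((oxan-4-yl)carbonyl)amino on this saturated chain carbon is an 11-fold higher number from compound 3 to compound 4 (1.05 log units; beyond the scatter), whereas adding the methyl on the chain carbon gave a 2.5-fold higher number from compound 2 to compound 3 (0.40 log units; beyond the scatter). The number at this position therefore depends strongly on the group carried there, although compound 4 still gives 17 nM without the aromatic ring of the group it lost. No measurement here explains the size of this step.

The change alters several things at once, replacing the five-membered ring and the aromatic ring with a six-membered non-aromatic ring and adding a hydrogen-bond donor, so the shown compounds cannot say which of these matters. A benzoylamino group at the same place would keep the amide hydrogen while restoring an aromatic ring of carbon, and could help separate these features.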